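This account rests on a few compounds, and the source may have more. Where it says the series, first, only, none or still open, it means among the compounds named here.

Measured in an ADME assay on NIH3T3 cells (Mus musculus) for cytotoxicity, read by XTT assay, with a stated time of 24 h; on this read-out lower numbers stand for stronger inhibition and higher numbers for weaker inhibition:
compound 1 `Cn1nnnc1SCC(=O)N/N=C/c1ccccc1` gives 9700000 nM
compound 2 `Cn1nnnc1SCC(=O)N/N=C/c1ccc(O)cc1` gives 632000 nM
compound 3 `Cn1nnnc1SCC(=O)N/N=C/c1ccccc1[N+](=O)[O-]` gives 2020000 nM

Among these three numbers compound 3 stands second highest: compound 2 sits lower, and compound 1 sits higher by a 4.8-fold lower number from compound 1 to compound 3 (0.68 log units; beyond the scatter). Compound 4 `Cn1nnnc1SCC(=O)N/N=C/c1ccccc1F` is not yet measured; it differs from compound 3 by fluoro in place of nitro on an aromatic carbon, placed on an aromatic carbon of a six-membered aromatic ring of carbon only, ortho to a large group. Going by the values given here, the steps that bear on this are the two ring substitutions of hydrogen, a 15-fold lower number from compound 1 to compound 2 (1.19 log units; beyond the scatter) and a 4.8-fold lower number from compound 1 to compound 3 (0.68 log units; beyond the scatter), both lowering the number. Fluoro is, by the counted difference, the smaller group, and a modest rise back toward the figure of compound 1 is expected, a 2.0-fold higher number from compound 3 to compound 4 (0.30 log units; within the scatter). The estimate for compound 4 is 4000000 nM, within 1500000 nM to 10000000 nM.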

Compound 4, half-maximal inhibitory concentration: 2000000 nM
The estimate for compound 4 lay 2.0-fold (0.30 log units) above the measured number; low and high end bracket the measured number.
By their numbers in this assay, from the lowest: compound 2; then compounds 4 and 3 (each within the scatter of the next); then compound 1.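

In this assay, the step from nitro to fluoro on this aromatic carbon, ortho to a large group, is a 1.0-fold lower number from compound 3 to compound 4 (0.00 log units; within the scatter), so a group of one heavy atom and a group of three cannot be told apart here. Fluoro in place of hydrogen gives a 4.9-fold lower number from compound 1 to compound 4 (0.69 log units; beyond the scatter), in line with the step seen for nitro, so the lowering at this place does not differ between these two groups. Nothing available gives a reason for this. As far as these compounds go, whether an amine or a methoxy group on this same carbon would match them stays open, as does whether fluoro would give the same step on another carbon of the ring.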